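A few compounds are considered here, and "the series" means these few. Any claim that something is new, unique, unknown or untested is made for them only; others in the source may bear on it.

Compound 1 `CCN(CC)S(=O)(=O)c1ccc(NC(=O)c2ccccc2)c2ccccc12` sits at a limit of an assay on L1.2 cells for binding affinity to C-C chemokine receptor type 8 (Homo sapiens) (a higher number here means a weaker inhibitor, a lower number a stronger inhibitor), rather than at a number: in this assay compound 1 gives > 30000 nM, which is the limit of > 30000 nM in this assay, at which 1 of the 2 values shown sits. For the measured compounds named here, compound 2 `CCC(=O)N1CCC(NS(=O)(=O)c2ccc(NC(=O)c3ccccc3C)c3ccccc23)CC1` is the only compound with a measured number, and in this assay compound 2 gives 2.5 nM. Compound 3 `CNC(=O)N1CCC(NS(=O)(=O)c2ccc(NC(=O)c3ccccc3C)c3ccccc23)CC1` differs from compound 2 in one place: methylamino in place of ethyl on a carbonyl carbon. Going by the values given here, no step between two measured compounds covers this change, so its direction is open. The expected step is a 1.4-fold higher number from compound 2 to compound 3 (0.15 log units; within the scatter), which is expected to stay within the scatter. Compound 3 is estimated at 3.5 nM in this assay, with a range from 1 nM to 12 nM.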

Compound 3, inhibition constant: 0.7 nM
For compound 3 the middle estimate is 5.0-fold (0.70 log units) above the measured one; measured number below the stated range.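

In this assay, for the compounds shown here, methylamino in place of ethyl on the carbonyl carbon gives a 3.6-fold lower number from compound 2 to compound 3 (0.55 log units; beyond the scatter), the first reading of a change at this position. The two groups have the same heavy-atom count, yet the step lies beyond the scatter; methylamino carries a hydrogen-bond donor and ethyl none. Nothing shown here accounts for the step. Going by these compounds, whether that donor matters stays open, and dimethylamino or methoxy on the same carbonyl carbon would address it. Longer chains such as ethylamino or propylamino also remain unexplored in the compounds shown.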